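Swapping phenyl for sec-butyl on a hydantoin-like core

This account rests on a few compounds, and the source may have more. Where it says the series, first, only, none or still open, it means among the compounds named here.

Compound 1 `CCC(C)C(NC(=O)NO)C(=O)NC1CCCCC1` gives 89000 nM in a functional assay on L1210 cells (Mus musculus) for inhibition; a lower number here means a stronger inhibitor, a higher number a weaker inhibitor. Compound 2 `O=C1NC(c2ccccc2)C(=O)N1Cc1ccccc1` gives > 200000 nM in this assay; that figure is a limit of the assay, not a measured number. Compound 2 therefore sits at the weak end of what is shown, at the limit of > 200000 nM in this assay, at which 1 of the 2 values shown sits, so its true value is not pinned down. Within the data shown here, no step between two measured compounds is available to guide the next change.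

Compound 3 `CCC(C)C1NC(=O)N(Cc2ccccc2)C1=O` differs from compound 2 in one place: sec-butyl in place of phenyl on a saturated ring carbon. The hydroxyurea of compound 1 is not part of either compound 2 or compound 3, so its value says nothing about this swap. Because compound 2 stands only at a limit, the direction of the step cannot be read from the data.

Compound 3 is expected to remain weak, near the limit, with the estimated step from compound 2 to compound 3 being a number no higher from compound 2 to compound 3 (the limit leaves the size open). Compound 3 is estimated at 200000 nM, within a range from 60000 nM to 700000 nM.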

Compound 3, half-maximal inhibitory concentration: > 200000 nM
Compound 3 was reported as a limit; the forecaster's own chance of this, stated with the estimate: 60%; the middle value lies on the limit itself.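

Among these compounds, compound 2 and compound 3 are both reported only as limits of the assay, not as numbers, so no step from one to the other can be read. The compounds shown leave open how strongly either one truly inhibits, and whether sec-butyl in place of phenyl changes that at all.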